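The source may hold more compounds than are shown below. What is called first, only, known or untested is meant among the compounds shown, and "the series" means these compounds.

Measured compounds:
compound 1, `C/C(=C\C(=O)Nc1ccccc1OCCCC(=O)O)c1ccc2c(ccn2Cc2ccc(C)cc2)c1`, 88 nM;
compound 2, `CCCCCC(c1ccccc1)n1ccc2cc(/C(C)=C/C(=O)Nc3ccccc3OCCCC(=O)O)ccc21`, 25 nM.

Among the compounds with values here, in an assay on Prostate gland for inhibition of steroid 5-alpha-reductase (Rattus norvegicus) (on this read-out higher numbers stand for weaker inhibition and lower numbers for stronger inhibition), compound 2 gives the lower of the two numbers, its only neighbour being compound 1. Compound 3, `C/C(=C\C(=O)Nc1ccccc1OCCCC(=O)O)c1ccc2c(ccn2C(c2ccccc2)C(C)C)c1`, differs from compound 2 by isopropyl in place of pentyl on a saturated chain carbon bound to an aromatic carbon and an aromatic nitrogen. Within the data shown here, the one measured step that touches this position, a 3.5-fold lower number from compound 1 to compound 2 (0.55 log units; beyond the scatter), came with the appearance of the 1-phenylhexyl group; trimming its chain to isopropyl keeps part of that change, so a small rise in number, at most around the scatter, is expected, a 1.6-fold higher number from compound 2 to compound 3 (0.20 log units; within the scatter). Compound 3 is therefore estimated at 40 nM, between 18 nM and 90 nM.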

Compound 3, half-maximal inhibitory concentration: 25 nM
Compound 3: middle estimate off by 1.6-fold (0.20 log units), on the high side; low and high end bracket the measured number.
By their numbers in this assay, from the lowest: compounds 2 and 3 (each within the scatter of the next); then compound 1.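

In this assay isopropyl in place of pentyl gives no change at the digits printed from compound 2 to compound 3 (within the scatter) and so a long straight chain is not needed on this saturated chain carbon to keep the number. The branched 2-methyl-1-phenylpropyl group gives a 3.5-fold lower number from compound 1 to compound 3 (0.55 log units; beyond the scatter) and so matches the step seen with 1-phenylhexyl. No measured evidence here offers a reason for this. On these data alone, whether methyl or a ring such as cyclohexyl on this same carbon would keep the number stays open. So does the outcome of placing a hydroxyl or an amine on this chain.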